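Valine to isoleucine side chain in a hydroxyurea amide

The source may report more compounds than this note shows. Statements on the series, on what has been measured and on what is new or still open speak of the compounds shown alone.

The study compares three measured compounds and one that awaits measurement. Compound 1 `CCC(C)C(NC(=O)n1nnc2ccccc21)C(=O)NC1CCCCC1` carries a sec-butyl chain and a cyclohexyl amide; in a functional assay on CCRF-CEM cells (Homo sapiens) for inhibition (on this read-out lower numbers stand for stronger inhibition and higher numbers for weaker inhibition), compound 1 gives 107000 nM. Compound 2 `CCC(C)C(NC(=O)n1nnc2ccccc21)C(=O)NCc1ccccc1` differs by a benzyl in place of cyclohexyl on an amide-type nitrogen, and in this assay compound 2 gives 164000 nM; the step of a 1.5-fold higher number from compound 1 to compound 2 (0.19 log units; within the scatter) is within the scatter. Compound 3 `CC(C)C(NC(=O)NO)C(=O)NC1CCCCC1` replaces the acyl-benzotriazole urea with a hydroxyurea and keeps the cyclohexyl amide. For compound 3 this assay reports only a limit, > 100000 nM, which is the same limit as the limit of > 100000 nM in this assay, at which 1 of the 3 values shown sits. Compound 4 `CCC(C)C(NC(=O)NO)C(=O)NC1CCCCC1` differs from compound 3 by methyl in place of hydrogen on a saturated chain carbon, three bonds along the chain from an amide-type nitrogen and a carbonyl carbon. Going by the values given here, no measured step covers a change at this saturated chain carbon; the only measured step, between compound 1 and compound 2, concerns the amide nitrogen and is within the scatter. Compound 1 shows that a sec-butyl chain, with a different urea, gives a number near 107000 nM. Compound 4 is therefore expected to remain weak, with an expected step that the limit leaves unreadable from compound 3 to compound 4. The estimate for compound 4 in this assay is 150000 nM, expected to fall between 40000 nM and 600000 nM.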

Compound 4, half-maximal inhibitory concentration: 153000 nM
The estimate for compound 4 lay 1.0-fold (0.01 log units) below the measured number; low and high end bracket the measured number.
By their numbers in this assay, from the lowest: compounds 1, 4 and 2 (each within the scatter of the next).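

The step from compound 3 to compound 4 cannot be read, because compound 3 has only a limit and not a number: the limit of > 100000 nM in this assay, at which 1 of the 4 values shown sits. The compounds shown leave open how large the change from isopropyl to sec-butyl is in this assay.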